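The compounds below may be only part of what the source reports. "The series", "measured", "known", "first", "only" and "open" are said of these compounds alone.

For the measured compounds named here, compound 2 `OCC(NCc1nc2c(OCC3CCCCC3)cccc2[nH]1)c1ccccc1` gives 20000 nM in an assay on cells for inhibition of interleukin-5 receptor subunit alpha (Mus musculus), read by WST assay, with a stated time of 48 h, in the presence of a further agent that is not named here (on this read-out lower numbers stand for stronger inhibition and higher numbers for weaker inhibition), one of only two numbers so far; the other is compound 1 `OCCCNCc1nc2c(OCC3CCCCC3)cccc2[nH]1`, which gives 28500 nM and lies within the scatter of compound 2: a 1.4-fold lower number from compound 1 to compound 2 (0.15 log units; within the scatter). Compound 3 `OCCC(NCc1nc2c(OCC3CCCCC3)cccc2[nH]1)c1ccccc1` differs from compound 2 by hydroxymethyl in place of hydroxy on a saturated chain carbon, two bonds along the chain from an amine nitrogen and an aromatic carbon. Going by the values given here, no measured step alters that carbon's substituent; the single recorded step, from compound 1 to compound 2, exchanged the whole amine substituent and stayed within the scatter, so no movement beyond the scatter is expected in this assay. For compound 3 the estimate is 20000 nM, with a range from 8000 nM to 50000 nM. The expected step, no change at the digits printed from compound 2 to compound 3 (within the scatter), is judged to stay within the scatter.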

Compound 3, half-maximal inhibitory concentration: 22000 nM
Estimate against measurement, compound 3: 1.1-fold (0.04 log units) below; the range from low to high includes it.
By their numbers in this assay, from the lowest: compounds 2, 3 and 1 (each within the scatter of the next).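

In this assay, the one-carbon extension from hydroxy to hydroxymethyl at this position gives a 1.1-fold higher number from compound 2 to compound 3 (0.04 log units; within the scatter), so the read-out does not separate the two groups. For the compounds shown here, with the phenyl carried on this carbon, the first step to change only that substituent gives a 1.3-fold lower number from compound 1 to compound 3 (0.11 log units; within the scatter), so phenyl in place of hydrogen is likewise not separated. No evidence bearing on these results is available. As far as these compounds go, the effect of a carboxylic acid or an amine in place of the terminal hydroxy remains open. So does the effect of a longer chain, such as 3-hydroxypropyl, at this carbon.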